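The source may report more compounds than this note shows. Statements on the series, on what has been measured and on what is new or still open speak of the compounds shown alone.

Three measured compounds share the same inactive level. In a functional assay on MCF7 cells (Homo sapiens) for cytotoxicity, read by colorimetric assay and MTT assay (on this read-out higher numbers stand for weaker inhibition and lower numbers for stronger inhibition), compound 1 `COc1cccc2cc(-c3ccccc3)c(O)nc12` gives 10000 nM, compound 2 `COc1ccc2cc(-c3ccccc3)c(O)nc2c1` gives 10000 nM, and compound 3 `COc1ccc(-c2cc3c(OC)cc(OC)cc3n(C)c2=O)cc1` gives 10000 nM. Compound 3 therefore stands level with compounds 1 and 2, with no difference beyond the scatter in either direction. Compound 4 `COc1ccc(-c2cc3c(OC)cc(OC)cc3n(CCCC#N)c2=O)cc1` differs from compound 3 by 2-cyanoethyl in place of hydrogen on a saturated chain carbon bound to an aromatic nitrogen. For the measured compounds named here, no measured pair shows what such an added chain does here, so the expectation rests on compound 3 alone. The step expected from compound 3 to compound 4 in this assay is no change at the digits printed from compound 3 to compound 4 (within the scatter), that is, no change beyond the scatter. Compound 4 is therefore estimated at 10000 nM, within a range from 3000 nM to 30000 nM.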

Compound 4, half-maximal inhibitory concentration: 10000 nM
For compound 4 middle estimate and measured number coincide at the digits printed, and the stated range covers the measured number.
By their numbers in this assay, from the lowest: compounds 1, 2, 3 and 4 (each within the scatter of the next).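

In this assay, for the compounds shown here, the swap of hydrogen for 2-cyanoethyl on a saturated chain carbon bound to an aromatic nitrogen gives no change at the digits printed from compound 3 to compound 4 (within the scatter) as the first reading at this place. Read one bond further out, methyl can become 3-cyanopropyl with the number staying at the level of compound 3. Nothing measured here offers a reason for this outcome.

Going by these compounds, whether an amine, a carboxylic acid or a longer chain at this place would move the number remains open. With all four compounds at one level, the set does not show what would lower it.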